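The source may hold more compounds than are shown below. What is called first, only, known or untested is meant among the compounds shown, and "the series" means these compounds.

Three compounds have been measured in a functional assay on MCF7 cells (Homo sapiens) for cytotoxicity, read by MTT assay, with a stated time of 48 h; on this read-out lower numbers stand for stronger inhibition and higher numbers for weaker inhibition:

Compound 1, `CNC(=O)CSc1nc2ccc(NC(=O)c3ccc(Cl)cc3)cc2s1`, gives 29400 nM.
Compound 2, `O=C(CSc1nc2ccc(NC(=O)c3ccc(Cl)cc3)cc2s1)NCc1ccc(Cl)cc1`, gives 29300 nM.
Compound 3, `COc1ccc(CNC(=O)CSc2nc3ccc(NC(=O)c4ccc(Cl)cc4)cc3s2)cc1`, gives 19200 nM.

Compound 2 holds the second highest of these three numbers. Its nearest neighbour is reached by a 1.0-fold lower number from compound 1 to compound 2 (0.00 log units; within the scatter), its furthest by a 1.5-fold lower number from compound 2 to compound 3 (0.18 log units; within the scatter); both gaps lie within the scatter, so the three compounds cannot be told apart on this read-out.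

Compound 4, `COc1ccccc1C(=O)Nc1ccc2nc(SCC(=O)NCc3ccc(Cl)cc3)sc2c1`, differs from compound 2 in one place: 2-methoxyphenyl in place of 4-chlorophenyl on a carbonyl carbon. The three measured steps all sit elsewhere, on the saturated chain carbon bound to an amide-type nitrogen: a 1.5-fold lower number from compound 1 to compound 3 (0.19 log units; within the scatter), and the methoxy-for-chloro swap of a 1.5-fold lower number from compound 2 to compound 3 (0.18 log units; within the scatter), which also stays within the scatter. For the measured compounds named here, none of them touches the carbonyl carbon where compound 4 changes, so no measured step bears directly on it. With every step seen so far within the scatter, no step beyond the scatter is expected for a 1.1-fold lower number from compound 2 to compound 4 (0.05 log units; within the scatter). Compound 4 is therefore expected to give about 26000 nM, with a likely range from 11000 nM to 62000 nM.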

Compound 4, half-maximal inhibitory concentration: 1100 nM
Beside the measured number, compound 4's estimate is 24-fold (1.37 log units) above it, and the stated range ends above it.
By their numbers in this assay, from the lowest: compound 4; then compounds 3, 2 and 1 (each within the scatter of the next).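

In this assay, for the compounds shown here, the carbonyl carbon bound to the amide-type nitrogen is the first place in these compounds where a single change moves the number beyond the scatter: 2-methoxyphenyl in place of 4-chlorophenyl gives a 27-fold lower number from compound 2 to compound 4 (1.43 log units; beyond the scatter). The changes among compound 1, compound 2 and compound 3 on the saturated chain carbon all stayed within the scatter, so the read-out responds to this change on the carbonyl carbon as it did to none of those. Nothing available accounts for a step of this size.

The change replaces chloro with methoxy and also alters the numbered position of the substituent, so the compounds shown cannot separate the two; 2-chlorophenyl and 4-methoxyphenyl on the same carbonyl carbon would bear on that question, and unsubstituted phenyl would show what either substituent contributes. Going by these compounds, it also remains open whether other groups on this ring, such as an amine or a carboxylic acid, would be tolerated, and whether the 2-methoxyphenyl step would hold with the methyl or 4-methoxyphenyl chain ends of compound 1 and compound 3.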